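Swapping an aryl ketone for a dicyanoethenyl group

The compounds below may be only part of what the source reports. "The series", "measured", "known", "first", "only" and "open" are said of these compounds alone.

Measured compounds:
Compound 1 `CC1(C)C=C(n2ccccc2=O)c2cc(C(=O)c3ccccc3)ccc2O1` gives 6.21 in a functional assay (trachea) with Rattus norvegicus as the target; a lower number here means a less potent compound, a higher number a more potent compound, by a factor of ten per unit of this negative logarithm.
Compound 2 `CC1(C)C=C(n2ccccc2=O)c2cc(C(=O)c3ccco3)ccc2O1` gives 5.92.
Compound 3 `Cc1ccccc1C(=O)c1ccc2c(c1)C(n1ccccc1=O)=CC(C)(C)O2` gives 6.25.

Compound 3 stands at the top of these three numbers, but its gap to compound 1, a number 0.04 log units higher from compound 1 to compound 3 (within the scatter), lies within the scatter, so the two cannot be told apart; only compound 2 sits clearly lower, as a number 0.33 log units higher from compound 2 to compound 3 (beyond the scatter) shows. Compound 4 `CC1(C)C=C(n2ccccc2=O)c2cc(C=C(C#N)C#N)ccc2O1` has not yet been measured. It differs from compound 3 in one place: 2,2-dicyanoethenyl in place of (2-methylphenyl)carbonyl on an aromatic carbon.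

The three known steps all keep the carbonyl and exchange only the group attached to it. Their sizes were a number 0.29 log units lower from compound 1 to compound 2 (within the scatter), a number 0.04 log units higher from compound 1 to compound 3 (within the scatter) and a number 0.33 log units higher from compound 2 to compound 3 (beyond the scatter), so changing that group moved the numbers little. None of the steps removes the carbonyl or introduces nitrile groups, so they bear on the new change only loosely. The expectation is therefore a step of modest size, slightly downward, a number 0.25 log units lower from compound 3 to compound 4 (within the scatter), with wide uncertainty. Compound 4 is estimated to give 6, in a range from 5.3 to 6.7.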

Compound 4, logarithm of the reciprocal of the active concentration, log(1/C): 6.3
Compound 4: middle estimate off by 0.30 log units, on the low side; the range from low to high includes it.
By their numbers in this assay, from the lowest: compounds 2, 1, 3 and 4 (each within the scatter of the next, the first and the last beyond it).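

In this assay the step of a number 0.05 log units higher from compound 3 to compound 4 (within the scatter) and the step of a number 0.09 log units higher from compound 1 to compound 4 (within the scatter) leave compound 4 indistinguishable from compounds 3 and 1, so on this aromatic carbon a group with no ring and no carbonyl, 2,2-dicyanoethenyl, matches (2-methylphenyl)carbonyl and benzoyl. For the compounds shown here, until now every compound carried a carbonyl bearing an aromatic ring, and the earlier steps could not show that the number survives the loss of both together. Only the step of a number 0.38 log units higher from compound 2 to compound 4 (beyond the scatter) lies beyond the scatter, and it is modest, so among these four compounds (furan-2-yl)carbonyl is the one group that stands apart from the rest, while no measurement shown here offers an explanation for any of these results.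

The compounds shown leave open how much of the group on this carbon is needed at all, as a plain hydrogen, a single nitrile, an amine or a carboxylic acid there could show. They also leave open whether both nitrile groups matter, a question that an ethenyl group carrying only one nitrile would address.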